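Moving the ether on the benzyl ring of compound 2

This account rests on a few compounds, and the source may have more. Where it says the series, first, only, none or still open, it means among the compounds named here.

Compound 1 `COc1cccc(OC)c1OCCNCCOc1ccccc1OCc1ccccc1C` gives 7.81 in a functional assay on Vas deferens for antagonist activity at Alpha-1A adrenergic receptor (Rattus norvegicus) (a lower number here means a less potent compound, a higher number a more potent compound, by a factor of ten per unit of this negative logarithm), and compound 2 `COc1ccccc1COc1ccccc1OCCNCCOc1c(OC)cccc1OC` gives 8.53, the higher of the two numbers. The step of a number 0.72 log units higher from compound 1 to compound 2 (beyond the scatter) is the only one known. Compound 3 `CCOc1ccc(COc2ccccc2OCCNCCOc2c(OC)cccc2OC)cc1` differs from compound 2 by 4-ethoxyphenyl in place of 2-methoxyphenyl on a saturated chain carbon bound to an oxygen on an aromatic ring. Going by the values given here, no measured step bears on that change directly, since the step from compound 1 to compound 2 concerned methyl against methoxy at a single place. A small loss is therefore expected, a number 0.33 log units lower from compound 2 to compound 3 (beyond the scatter), with wide uncertainty. Compound 3 is estimated at 8.2, between 7.4 and 9.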

Compound 3, negative logarithm of the antagonist equilibrium constant: 8.5
Estimate against measurement, compound 3: 0.30 log units below, and the stated range covers the measured number.
By their numbers in this assay, from the lowest: compound 1; then compounds 3 and 2 (each within the scatter of the next).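

In this assay, the step of a number 0.03 log units lower from compound 2 to compound 3 (within the scatter) shows that 2-methoxyphenyl and 4-ethoxyphenyl cannot be told apart at this place, so the ether group can differ in both its location and its length without a clear change in the number. The step of a number 0.69 log units higher from compound 1 to compound 3 (beyond the scatter) shows that compound 1, with its 2-methylphenyl, stays apart from compound 3 as it does from compound 2. No evidence here explains these results. As far as these compounds go, since location and length changed together, their separate contributions remain open, and 4-methoxyphenyl or 2-ethoxyphenyl would separate them. From the compounds shown here alone, how an amine or a carboxylic acid would fare at this place is also open.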